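Chloro for dimethyl on a diaryl urea: a small step

A few compounds are considered here, and "the series" means these few. Any claim that something is new, unique, unknown or untested is made for them only; others in the source may bear on it.

Three compounds share a core and differ only in the aromatic group on one urea nitrogen. In a functional assay on MGC-803 cells (Homo sapiens) for antiproliferative activity, read by MTT assay, with a stated time of 48 h (a higher number here means a weaker inhibitor, a lower number a stronger inhibitor), compound 2 `Cc1ccc(NC(=O)Nc2cccc(CNc3nccnc3Cl)c2)c(C)c1` gives 10100 nM, compound 3 `CS(=O)(=O)c1ccc(NC(=O)Nc2cccc(CNc3nccnc3Cl)c2)cc1` gives 12300 nM, and compound 1 `CCc1ccc(NC(=O)Nc2cccc(CNc3nccnc3Cl)c2)c(CC)c1` gives 6130 nM; all three numbers lie within the usual scatter of one another, so no order among them can be read. Compound 4 `O=C(Nc1cccc(Cl)c1)Nc1cccc(CNc2nccnc2Cl)c1` has not yet been measured in this assay. It differs from compound 2 by 3-chlorophenyl in place of 2,4-dimethylphenyl on an amide-type nitrogen. For the measured compounds named here, with no step between measured compounds to lean on, the expectation is a change of no more than the scatter, in either direction: the step from compound 2 to compound 4 is estimated at a 1.1-fold lower number from compound 2 to compound 4 (0.05 log units; within the scatter). Compound 4 is therefore expected to give about 9000 nM, plausibly between 4000 nM and 20000 nM.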

Compound 4, half-maximal inhibitory concentration: 5330 nM
For compound 4 the middle estimate is 1.7-fold (0.23 log units) above the measured one; measured number inside the range.
By their numbers in this assay, from the lowest: compounds 4, 1, 2 and 3 (each within the scatter of the next, the first and the last beyond it).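

In this assay, for the compounds shown here, the change to 3-chlorophenyl on the amide-type nitrogen gives the first readable step at this position, a 1.9-fold lower number from compound 2 to compound 4 (0.28 log units; within the scatter), so these two aryl groups cannot be told apart here. The series does now hold its first pair beyond the scatter of each other, compound 4 at 5330 nM and compound 3 at 12300 nM. No measurement shown bears on this result. From the compounds shown here alone, whether an amine or a carboxylic acid on this aromatic ring would give a step beyond the scatter stays open.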